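The source may hold more compounds than are shown below. What is called first, only, known or untested is meant among the compounds shown, and "the series" means these compounds.

Working notes on the furan-carbohydrazide series.

Two compounds have a number in a functional assay on KB cells (Homo sapiens) for inhibition, read by sulforhodamine B assay, with a stated time of 48 h, tested at 10 uM (a higher number here means more inhibition of growth at the concentration tested, a lower number less inhibition of growth), so far. Compound 1 `O=C(N/N=C/c1ccccc1O)c1ccc(-c2ccc(F)cc2)o1` gives 53.9% in this assay. Compound 2 `Cc1cccc(/C=N/NC(=O)c2ccc(-c3ccccc3[N+](=O)[O-])o2)c1` gives 10.3% in this assay. Compound 1 thus stands highest of the two numbers; the nearest, compound 2, lies a good way lower, and that gap is beyond the usual scatter. Among the measured compounds shown here, the two compounds differ in more than one place, so their values show only that compound 1 inhibits growth more than compound 2, not what any single change is worth.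

The next compound, compound 3 `O=C(N/N=C/c1ccccc1Cl)c1ccc(-c2ccc(F)cc2)o1`, differs from compound 1 in one place: chloro in place of hydroxy on an aromatic carbon. For the measured compounds named here, no pair of measured compounds shows this change, so its size is unknown here; it is taken to be within the scatter or a small loss, not a gain, given that compound 1 already holds the highest number. The expected step from compound 1 to compound 3 is a number 11.9 percentage points lower from compound 1 to compound 3 (beyond the scatter). Compound 3 is accordingly estimated at 42% in this assay, with a range from 15% to 65%.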

Compound 3, percent growth inhibition at one concentration: 19.3%
Estimate against measurement, compound 3: 22.7 percentage points above; the measured number falls inside the stated range.
By their numbers in this assay, from the lowest: compounds 2 and 3 (each within the scatter of the next); then compound 1.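

With the rest of the structure held constant, chloro in place of hydroxy on an aromatic carbon, ortho to a large group, gives a number 34.6 percentage points lower from compound 1 to compound 3 (beyond the scatter) in this assay and gives the series its first single-change step. The earlier values differed in more than one place and could not be assigned to any one change, whereas this pair shows that growth inhibition at the concentration tested is sensitive to the group at this position. The hydroxy of compound 1 goes with the higher number in this pair, but no measurement shown here explains why the step is so large.

Going by these compounds, it remains open whether the loss follows from hydroxy leaving or from chloro entering, and a methoxy group or an amine at this position would help to separate the two. On these data alone, it is also open whether the same change carries a step of this size on a core other than that of compound 1.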